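Swapping 4-aminopiperidin-1-yl for hydroxy on a carbonyl carbon

The compounds below may be only part of what the source reports. "The series", "measured", "known", "first", "only" and "open" are said of these compounds alone.

In a physicochemical assay for solubility, read by HPLC, using the shake flask method, with a stated time of 2 h, at pH 2 (on this read-out lower numbers stand for lower solubility and higher numbers for higher solubility), compound 1 `Nc1ncc(-c2ccc(C(=O)N3CCC(N)CC3)cc2)nc1-c1ccc(C(F)(F)F)cc1` gives 200000 nM. That number sits level with the other two measured compounds, all within the usual scatter: compound 2 `Nc1ccc(-c2nc(-c3ccc(S(=O)(=O)C4CC4)cc3)cnc2N)cn1` gives 212000 nM, and compound 3 `N#Cc1ccc(-c2cnc(N)c(-c3ccc(N)nc3)n2)cc1` gives 208000 nM.

The next compound to be tested, compound 4 `Nc1ncc(-c2ccc(C(=O)O)cc2)nc1-c1ccc(C(F)(F)F)cc1`, comes from compound 1 through a single structural change: hydroxy in place of 4-aminopiperidin-1-yl on a carbonyl carbon. Put simply, hydroxy takes the place of 4-aminopiperidin-1-yl on a carbonyl carbon, turning (4-aminopiperidin-1-yl)carbonyl into carboxy.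

The measurements offer little guidance on this change. For the measured compounds named here, the only measured single-place step, a 1.0-fold lower number from compound 2 to compound 3 (0.01 log units; within the scatter), lies within the scatter, but it puts cyano in place of cyclopropylsulfonyl on an aromatic carbon, which is a different exchange altogether. Going by the values given here, no measured compound carries carboxy, so there is no direct precedent, and the direction of the step in this assay remains a judgement call. A lower number is the more likely outcome, but a result level with compound 1 cannot be ruled out.

The expected step is a 6.7-fold lower number from compound 1 to compound 4 (0.82 log units; beyond the scatter), an estimate with wide uncertainty. For compound 4 the estimated value is 30000 nM, with an expected range from 3000 nM to 220000 nM.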

Compound 4, solubility: < 5000 nM
Compound 4: only a limit was reported; the forecaster's own chance of this, stated with the estimate: 15%; middle value at least 6.0-fold (0.77 log units) from the limit.
By their numbers in this assay, from the lowest: compounds 1, 3 and 2 (each within the scatter of the next). At a limit, below all of these: compound 4.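

In this assay, putting hydroxy in place of 4-aminopiperidin-1-yl on a carbonyl carbon gives an at least 40-fold lower number from compound 1 to compound 4 (1.60 log units; beyond the scatter), which shows that this position can move the read-out by a large amount even though the shared core stays the same. On these data alone, the result for compound 4 is a limit rather than an exact number, so the true size of the step remains unknown beyond the minimum printed with it: the limit of < 5000 nM in this assay, at which 1 of the 4 values shown sits. The only earlier step, a 1.0-fold lower number from compound 2 to compound 3 (0.01 log units; within the scatter), lay within the scatter and involved a different exchange on an aromatic carbon, so this is the first step shown that goes beyond the scatter.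

As far as these compounds go, what remains open is which part of the exchange matters, as this single step removes the ring and the amine of 4-aminopiperidin-1-yl and introduces carboxy all at once. A plain piperidin-1-yl group on the same carbonyl carbon would test the amine alone, while a methyl ester would show what happens when the carbonyl carbon carries neither the ring nor the hydroxy.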